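Adding a Methyl to a Furanocoumarin-Type Core: Two Settings

A few compounds are considered here, and "the series" means these few. Any claim that something is new, unique, unknown or untested is made for them only; others in the source may bear on it.

Of the compounds shown here, three from this set share a core and have been tested in a functional assay on SK-BR-3 cells (Homo sapiens) for cytotoxicity, read by sulforhodamine B assay, with a stated time of 72 h; on this read-out lower numbers stand for an effect already at smaller amounts and higher numbers for an effect only at larger amounts of compound. Compound 1 `Cc1cccc(-c2cc3occ(C)c3c(=O)o2)c1` gives 1.5 uM in this assay. Compound 2 `Cc1cc(C)cc(-c2cc3occ(C)c3c(=O)o2)c1` gives 22.4 uM. The change between them, (methyl in place of hydrogen on an aromatic carbon), leads to a 15-fold higher number from compound 1 to compound 2 (1.17 log units; beyond the scatter). Compound 3 `COc1cc(OC)cc(-c2cc3occ(C)c3c(=O)o2)c1` gives 0.28 uM, the lowest number of the three; its distance from compound 1 and from compound 2 lies beyond the usual scatter. How the core of compound 3 differs from that of compound 1 is not broken down here.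

Compound 4 `COc1cc(OC)cc(-c2cc3oc(C)c(C)c3c(=O)o2)c1` has not yet been measured. It differs from compound 3 by methyl in place of hydrogen on an aromatic carbon. Within the data shown here, this is the same kind of change as the one from compound 1 to compound 2, but not the same: there the methyl entered on a six-membered aromatic ring of carbon only, meta to a large group and meta to a methyl group, whereas here it enters on a five-membered aromatic ring with one oxygen, part of a fused system, next to the ring oxygen and next to the ring atom that bears a methyl group. Among the measured compounds shown here, the only measured example of such a change weakened the effect, but the setting differs, so compound 4 is expected to show a smaller step, a 2.9-fold higher number from compound 3 to compound 4 (0.46 log units; beyond the scatter), than the earlier one. Compound 4 is estimated at 0.8 uM in this assay, between 0.25 uM and 3 uM.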

Compound 4, concentration for half-maximal effect: > 66.7 uM
Compound 4: only a limit was reported; the forecaster's own chance of this, stated with the estimate: 5%; middle value at least 83-fold (1.92 log units) from the limit.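

Methyl in place of hydrogen on an aromatic carbon gives an at least 230-fold higher number from compound 3 to compound 4 (2.37 log units; beyond the scatter) in this assay, and this step can be set beside the earlier one: the same change on two cores in this assay, a 15-fold higher number (1.17 log units; beyond the scatter) from compound 1 to compound 2 and an at least 230-fold higher number (2.37 log units; beyond the scatter) from compound 3 to compound 4, at least 15-fold (1.20 log units) apart, beyond the scatter of two such steps. The reported value of compound 4 is > 66.7 uM and it is a limit of the assay, not a number, so the second step has a lower bound but no known size: the limit of > 66.7 uM in this assay, at which 1 of the 4 values shown sits. In these two pairs the direction of the change carried over from one core to the other while its size did not, but two pairs give no rule for the series, and they differ both in the core and in the ring that takes the methyl, which the data do not separate.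

From the compounds shown here alone, it stays open whether the same methyl on the five-membered aromatic ring of the core of compound 1 would give a step as large as the one seen on the core of compound 3. Only hydrogen and methyl are shown on that ring carbon, so it also stays open how an ethyl group, a longer chain, a hydroxyl group or an amine would fare at that place.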